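This account rests on a few compounds, and the source may have more. Where it says the series, first, only, none or still open, it means among the compounds named here.

Compound 1, `Oc1cccc2c1CCCC2c1c[nH]cn1`, gives 145 nM.
Compound 2, `CCS(=O)(=O)Nc1cc(C2CCCCC2)cc2c1CCCC2c1c[nH]cn1`, gives 891 nM.
Compound 3, `CCS(=O)(=O)Nc1cccc2c1CCCC2c1c[nH]cn1`, gives 1320 nM.

These three compounds were tested in an assay on isolated protein (Cricetulus griseus) for binding affinity to Alpha-1B adrenergic receptor (Mesocricetus auratus), read by radioligand binding; a lower number here means a stronger inhibitor, a higher number a weaker inhibitor. Compound 3 has the highest number of the three, so it is the weakest binder shown; compound 2 sits closest to it, separated only by a 1.5-fold higher number from compound 2 to compound 3 (0.17 log units; within the scatter), while compound 1 lies furthest away, with a 9.1-fold higher number from compound 1 to compound 3 (0.96 log units; beyond the scatter) between them.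

Compound 4, `COC(=O)Nc1cccc2c1CCCC2c1c[nH]cn1`, has not yet been measured. It differs from compound 3 in one place: methoxycarbonyl in place of ethylsulfonyl on a nitrogen on an aromatic ring.

Among the measured compounds shown here, no measured step swaps one group for another on this nitrogen, so no step bears directly on the change. For the measured compounds named here, the only step touching this position is the one from compound 1 to compound 3, a 9.1-fold higher number from compound 1 to compound 3 (0.96 log units; beyond the scatter), where the hydroxy group was replaced by (ethylsulfonyl)amino and the number rose well beyond the scatter. The methoxycarbonyl group that enters is close in size to the ethylsulfonyl that leaves, with the same count of hydrogen-bond acceptors and donors, so no large step is expected in this assay; the estimate leans slightly toward a lower number, which is the step of a 1.5-fold lower number from compound 3 to compound 4 (0.17 log units; within the scatter). For compound 4 the expected value is 900 nM, with a likely range from 300 nM to 3000 nM.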

Compound 4, inhibition constant: 10000 nM
Compound 4: middle estimate off by 11-fold (1.05 log units), on the low side; measured number above the stated range.
By their numbers in this assay, from the lowest: compound 1; then compounds 2 and 3 (each within the scatter of the next); then compound 4.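

On this nitrogen, the identity of the group matters more than the simple counts suggest: in this assay the swap gives a 7.6-fold higher number from compound 3 to compound 4 (0.88 log units; beyond the scatter), although methoxycarbonyl and ethylsulfonyl have the same count of hydrogen-bond donors and acceptors and are close in heavy-atom count. Among the compounds shown here, until now, the only step at this position was the change from hydroxy to (ethylsulfonyl)amino, and the corresponding change to (methoxycarbonyl)amino is clearly larger, at a 69-fold higher number from compound 1 to compound 4 (1.84 log units; beyond the scatter), so the rise in the number depends on what the nitrogen carries and not only on a substituted nitrogen taking the place of hydroxy. Nothing available here explains why these two groups differ so sharply.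

Still open, going by these compounds, is whether other groups on this nitrogen, such as acetyl or methylsulfonyl, would give numbers nearer that of compound 3 or that of compound 4, which would help separate the role of the sulfonyl from that of the chain attached to it. Also open, on these data alone, is whether cyclohexyl, whose step on the ethylsulfonyl series stays within the scatter, would behave the same way on compound 4.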